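A few compounds are considered here, and "the series" means these few. Any claim that something is new, unique, unknown or untested is made for them only; others in the source may bear on it.

Compound 2 `CCCCCC(C#CC(=O)OC)O/C=C/C(=O)OC` gives 1300 nM in a functional assay on SW1573 cells (Homo sapiens) for inhibition, with a stated time of 48 h (on this read-out higher numbers stand for weaker inhibition of growth and lower numbers for stronger inhibition of growth), the second highest of the three numbers. Compound 1 `CCCCC(C#CC(=O)OC)O/C=C/C(=O)OC` gives 420 nM; the step of a 3.1-fold higher number from compound 1 to compound 2 (0.49 log units; beyond the scatter) is modest yet beyond the scatter. Compound 3 `CCCCC[C@H](C#CC(=O)OC)O/C=C/C(=O)OC` gives 5500 nM; the step of a 4.2-fold higher number from compound 2 to compound 3 (0.63 log units; beyond the scatter) is likewise beyond the scatter, and the fact that one of compounds 2 and 3 is drawn with a defined configuration and the other without, at the place where they differ bears on it. Compound 4 `CCCCC[C@@H](C#CC(=O)OC)O/C=C/C(=O)OC` differs from compound 2 in that (the two compounds have the same atoms and bonds; at least one stereo element is drawn with a configuration in one of them and without one in the other: 1 of 2 stereo elements differ; a stereocentre at a saturated chain carbon is drawn without a configuration in compound 2 and S in compound 4). For the measured compounds named here, only the step from compound 2 to compound 3 bears on this change, and there the R configuration raised the number. Since compound 3 gives 5500 nM while compound 2 gives 1300 nM, the S configuration is expected to lower the number in this assay, probably within the scatter. For compound 4 the estimate is 700 nM, range 300 nM to 1600 nM, with an expected step of a 1.9-fold lower number from compound 2 to compound 4 (0.27 log units; within the scatter).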

Compound 4, concentration for 50% growth inhibition: 8400 nM
Estimate against measurement, compound 4: 12-fold (1.08 log units) below, and the stated range ends below it.
By their numbers in this assay, from the lowest: compound 1; then compound 2; then compounds 3 and 4 (each within the scatter of the next).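

With a 6.5-fold higher number from compound 2 to compound 4 (0.81 log units; beyond the scatter), the S configuration moves the number the same way as the R configuration in this assay, so both drawn forms stand above compound 2: the fact that one of compounds 2 and 4 is drawn with a defined configuration and the other without, at the place where they differ

The two drawn forms do not separate, with a 1.5-fold higher number from compound 3 to compound 4 (0.18 log units; within the scatter), so R against S at this saturated chain carbon shows no difference beyond the scatter: the fact that compounds 3 and 4 differ only in the configuration as drawn

Why compound 2, drawn without a configuration, gives a lower number than both compound 3 and compound 4 stays open. So does whether R and S also stay inseparable with a longer chain, or with a carboxylic acid in place of an ester.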